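Moving the methyl: compound 3 to compound 4

This account rests on a few compounds, and the source may have more. Where it says the series, first, only, none or still open, it means among the compounds named here.

In a functional assay on THP-1 cells (Homo sapiens) for inhibition (on this read-out higher numbers stand for weaker inhibition of growth and lower numbers for stronger inhibition of growth), compound 1 `Cc1noc(C)c1-c1ccc2c(c1)c(Cc1ccccc1)cn2CCCCCC(=O)NO` gives 15500 nM.
Compound 2 `Cc1noc(C)c1-c1ccc2c(c1)c(CCc1ccc(F)cc1)cn2CCCCCC(=O)NO` gives 15500 nM.
Compound 3 `Cc1ccccc1Cc1cn(CCCCCC(=O)NO)c2ccc(-c3c(C)noc3C)cc12` gives 15500 nM.

Compound 3 stands level with compounds 1 and 2 at the digits shown. The next structure, compound 4 `Cc1ccc(Cc2cn(CCCCCC(=O)NO)c3ccc(-c4c(C)noc4C)cc23)cc1`, has the same atoms joined differently: 4-methylphenyl in place of 2-methylphenyl on a saturated chain carbon bound to an aromatic carbon. In words, 4-methylphenyl stands in place of 2-methylphenyl on a saturated chain carbon bound to an aromatic carbon. For the measured compounds named here, three measured steps bear on this: no change at the digits printed from compound 1 to compound 3 (within the scatter) for the added methyl, no change at the digits printed from compound 2 to compound 3 (within the scatter) for the exchange of 4-fluorobenzyl for 2-methylphenyl, and no change at the digits printed from compound 1 to compound 2 (within the scatter) for the exchange of phenyl for 4-fluorobenzyl. No step beyond the scatter is therefore expected in this assay, and the expected step is a 1.0-fold lower number from compound 3 to compound 4 (0.01 log units; within the scatter). For compound 4 the estimated value is 15000 nM, with an expected range from 8000 nM to 21000 nM.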

Compound 4, concentration for 50% growth inhibition: 15500 nM
The estimate for compound 4 lay 1.0-fold (0.01 log units) below the measured number, and the stated range covers the measured number.
By their numbers in this assay, from the lowest: compounds 1, 2, 3 and 4 (each within the scatter of the next).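

In this assay the exchange of 2-methylbenzyl for 4-methylbenzyl reads as no change at the digits printed from compound 3 to compound 4 (within the scatter) and so does not separate the two placements of the methyl. The other comparisons agree: no change at the digits printed from compound 2 to compound 4 (within the scatter) against the 4-fluorobenzyl compound and no change at the digits printed from compound 1 to compound 4 (within the scatter) for methyl added to the phenyl of compound 1. Nothing at hand explains why these four values coincide.

Going by these compounds, whether any group at this place can shift the value remains open. An amine or a carboxylic acid on that phenyl, or a longer chain, would test this.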